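The source may hold more compounds than are shown below. What is called first, only, known or untested is meant among the compounds shown, and "the series" means these compounds.

For the measured compounds named here, in a functional assay on MDA-MB-231 cells (Homo sapiens) for antiproliferative activity, read by MTT assay, with a stated time of 24 h (on this read-out higher numbers stand for weaker inhibition and lower numbers for stronger inhibition), compound 1 `O=C(NNc1ccccc1Cl)c1cccc(NS(=O)(=O)c2cnc(O)nc2O)c1` gives 2090 nM, the only actual number available so far. Compound 2 `O=C(NNC(=O)c1ccccc1F)c1ccc(NS(=O)(=O)c2cnc(O)nc2O)cc1` is reported as > 20000 nM, which is a limit of the assay and not a number. Going by the values given here, compound 1 therefore stands alone as the one compound with a measured potency, and there is no measured pair to show how a single structural change moves the result.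

Compound 3 `O=C(NNC(=O)c1ccccc1Cl)c1cccc(NS(=O)(=O)c2cnc(O)nc2O)c1` comes from compound 1 through one change: (2-chlorophenyl)carbonyl in place of 2-chlorophenyl on an amine nitrogen. Cut one bond further out, the same difference reads (2-chlorophenyl)amino to ((2-chlorophenyl)carbonyl)amino.

Among the compounds with values here, with no direct precedent, any forecast for this assay is uncertain. The lean toward weaker inhibition rests on compound 2, whose > 20000 nM is a limit. The expected step of a 2.9-fold higher number from compound 1 to compound 3 (0.46 log units; beyond the scatter) is moderate and toward weaker inhibition, although a result close to that of compound 1 remains possible. For compound 3 the estimated value is 6000 nM, with an expected range from 1500 nM to 20000 nM.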

Compound 3, half-maximal inhibitory concentration: 2360 nM
The estimate for compound 3 lay 2.5-fold (0.41 log units) above the measured number, within the range that was stated.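

In this assay, the change from (2-chlorophenyl)amino to ((2-chlorophenyl)carbonyl)amino gives a 1.1-fold higher number from compound 1 to compound 3 (0.05 log units; within the scatter). For the compounds shown here, this is the first measured pair, and it shows that a carbonyl can enter at this amine nitrogen, adding one hydrogen-bond acceptor and two heavy atoms, without any readable difference in antiproliferative potency, since the two values cannot be told apart. Compound 2 also carries a carbonyl at this place, but it is reported only as a limit of the assay, not a number, and it differs from compound 3 in more than one place, so that limit cannot be tied to the carbonyl: the limit of > 20000 nM in this assay, at which 1 of the 3 values shown sits.

What the compounds shown leave open is how much room this amine nitrogen really offers, since a single pair cannot say whether a small group such as methyl, or a longer alkyl chain, would also leave the value near that of compound 1. On these data alone, it is also open whether the chlorine on the ring matters at all, which a plain phenyl, or a ring carrying an amine or a carboxylic acid, could help to settle.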